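Swapping a Pyrrolidinylmethyl Arm for a Nitrile

The source may report more compounds than this note shows. Statements on the series, on what has been measured and on what is new or still open speak of the compounds shown alone.

Of the compounds shown here, three have so far been tested in an assay on CHO cells for antagonist activity at melanin-concentrating hormone receptor 1 (Homo sapiens), read by luminescence and calcium flux, with a stated time of 10 min; a higher number here means a weaker inhibitor, a lower number a stronger inhibitor. Compound 1 `COc1cc(OC)cc(C(=O)N2CCC3(CCCN(Cc4cccc(C)c4)C3)C2)c1` gives 18000 nM. Compound 2 `N#Cc1cccc(-c2ccc(C3(c4nc5cc(C(F)(F)F)c(F)cc5[nH]4)CC34CCN(CC3CC3)CC4)cc2)c1` gives 4.8 nM. Compound 3 `CN1CCN(CCCN(c2nc3cc(F)c(F)cc3[nH]2)[C@@H]2CC[C@]3(c4cccc(CN5CCC[C@H]5CO)c4)C[C@@H]3C2)CC1` gives 3000 nM, the second highest of the three numbers: compound 1 stands higher and compound 2 far lower.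

Compound 4 `CN1CCN(CCCN(c2nc3cc(F)c(F)cc3[nH]2)[C@@H]2CC[C@]3(c4cccc(C#N)c4)C[C@@H]3C2)CC1` is compound 3 with one change: cyano in place of (2-(hydroxymethyl)pyrrolidin-1-yl)methyl on an aromatic carbon. Among the compounds with values here, no measured pair shows this change on its own, and compound 2, which also carries a cyano on a benzene ring, differs from compound 3 in too many other places to serve as a direct guide. A modest step toward a lower number, from compound 3 to compound 4, is expected, of about a 3.0-fold lower number from compound 3 to compound 4 (0.48 log units; beyond the scatter). In this assay compound 4 is estimated at 1000 nM, likely between 150 nM and 6000 nM.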

Compound 4, half-maximal inhibitory concentration: 21 nM
For compound 4 the middle estimate is 48-fold (1.68 log units) above the measured one; the whole stated range lies above it.
By their numbers in this assay, from the lowest: compound 2; then compound 4; then compound 3; then compound 1.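

On this aromatic carbon, meta to a large group, the (2-(hydroxymethyl)pyrrolidin-1-yl)methyl arm is not needed for activity in this assay, since replacing it with the far smaller cyano gives a 140-fold lower number from compound 3 to compound 4 (2.15 log units; beyond the scatter) with the rest of the molecule unchanged. This position is therefore highly sensitive to what it carries, and losing the pyrrolidine ring and its stereocentre goes with a much stronger inhibitor. No measurement at hand explains why this change has so large an effect.

Going by these compounds, whether a hydroxymethyl or an aminomethyl group on this carbon would behave like cyano or like the full arm stays open.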